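This account rests on a few compounds, and the source may have more. Where it says the series, first, only, none or still open, it means among the compounds named here.

The measured compounds and their results in a functional assay on HepG2 cells (Homo sapiens) for inhibition, read by MTT assay, with a stated time of 48 h, tested at 10 uM; on this read-out lower numbers stand for less inhibition of growth and higher numbers for more inhibition of growth at the one concentration tested:

Compound 1, `C#CCOc1ccc(/C=C/C(=O)c2ccc(Br)cc2)cc1`, gives 22%.
Compound 2, `C#CCOc1ccc(/C=C/C(=O)c2ccc(OC)cc2)cc1`, gives 25%.
Compound 3, `O=C(/C=C/c1ccc(OCc2cn(Cc3ccccc3)nn2)cc1)c1ccc(Br)cc1`, gives 22%.

Compounds 1 and 2 share one core and differ in a single place: methoxy in place of bromo on an aromatic carbon. The step this makes in this assay is a number 3 percentage points higher from compound 1 to compound 2 (within the scatter), so the two numbers cannot be told apart with confidence.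

Compound 3 has a different, larger core; how the two cores differ is not broken down here. In this assay compound 3 stands level with compound 1 at the digits printed, and the two together are the lowest of the three numbers, though all three lie close to one another.

Compound 4, `COc1ccc(C(=O)/C=C/c2ccc(OCc3cn(Cc4ccccc4)nn3)cc2)cc1`, has not been measured. It differs from compound 3 in one place: methoxy in place of bromo on an aromatic carbon. The position described for this change is the same, word for word, as that described for the change from compound 1 to compound 2, so it is the same change, now made on the core of compound 3.

Among the measured compounds shown here, the only guide to what it will do is the step between compound 1 and compound 2, which was small and within the scatter. On that basis the step from compound 3 to compound 4 in this assay is expected to be a number 3 percentage points higher from compound 3 to compound 4 (within the scatter), again a small one. Compound 4 is therefore estimated to give about 25%, with a likely range from 12% to 38%.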

Compound 4, percent growth inhibition at one concentration: 51%
Compound 4: the middle estimate sits 26 percentage points below what was measured; the measured number lies above the stated range.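

In this assay, putting methoxy in place of bromo gives a number 29 percentage points higher from compound 3 to compound 4 (beyond the scatter) and so produces a change that repeat measurements would not readily explain. Among the compounds shown here, this shows that, in this series, the size of this one change cannot simply be carried from one core to another, but with only two matched pairs it does not show why the size differs or whether methoxy would do the same on any other core. Set side by side, the two steps themselves differ by more than the usual spread of such measurements: the same change on two cores in this assay, a number 3 percentage points higher (within the scatter) from compound 1 to compound 2 and a number 29 percentage points higher (beyond the scatter) from compound 3 to compound 4, 26 percentage points apart, beyond the scatter of two such steps

The compounds shown carry only bromo and methoxy at this place, so it remains open whether another group there, such as an amine, a carboxylic acid or a longer chain like butoxy, would give a number closer to that of compound 3 or that of compound 4. They also leave open which part of the larger core of compound 3 matters for the bigger step, and whether the difference between compound 3 and compound 4 would hold at other concentrations.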